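Swapping ethoxy for fluoro on a 5-lipoxygenase inhibitor

A few compounds are considered here, and "the series" means these few. Any claim that something is new, unique, unknown or untested is made for them only; others in the source may bear on it.

Measured so far:
compound 1, `CC(=O)c1ccc(Nc2nc(-c3ccc(F)cc3)cs2)cc1`, 6700 nM
compound 2, `FC(F)(F)c1ccc(Nc2nc(-c3ccc(Cl)cc3)cs2)cc1`, 600 nM
compound 3, `CCOc1ccc(-c2csc(Nc3ccc(O)cc3)n2)cc1`, 30 nM

In an assay on isolated protein for inhibition of Polyunsaturated fatty acid 5-lipoxygenase (Homo sapiens), read by HPLC, with stated times of 15 min and 10 min (a higher number here means a weaker inhibitor, a lower number a stronger inhibitor), compound 3 gives the lowest number of the three, far from compound 2 and furthest from compound 1, both gaps well beyond the scatter. Compound 4, `Oc1ccc(Nc2nc(-c3ccc(F)cc3)cs2)cc1`, differs from compound 3 at one place on the six-membered aromatic ring of carbon only, para to a large group: fluoro in place of ethoxy on an aromatic carbon. For the measured compounds named here, no measured pair shows this change on its own, so its effect is unknown. Since compound 3 carries ethoxy and also gives 30 nM, a shift to a somewhat weaker inhibitor is expected, a 4.0-fold higher number from compound 3 to compound 4 (0.60 log units; beyond the scatter), while a result within the scatter remains possible. Compound 4 is estimated at 120 nM, in the range 30 nM to 500 nM.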

Compound 4, half-maximal inhibitory concentration: 60 nM
Compound 4: the middle estimate sits 2.0-fold (0.30 log units) above what was measured; low and high end bracket the measured number.
By their numbers in this assay, from the lowest: compounds 3 and 4 (each within the scatter of the next); then compound 2; then compound 1.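

In this assay, fluoro in place of ethoxy gives a 2.0-fold higher number from compound 3 to compound 4 (0.30 log units; within the scatter), so on this ring the smaller fluoro serves about as well as ethoxy. The other change to compound 4 counts for far more: with fluoro kept, hydroxy in place of acetyl gives a 110-fold lower number from compound 1 to compound 4 (2.05 log units; beyond the scatter). Nothing available explains either step.

The compounds shown leave open how an amine or a chain longer than ethoxy would read at the fluoro position. They also leave open whether a carboxylic acid could stand in for hydroxy.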